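This account rests on a few compounds, and the source may have more. Where it says the series, first, only, none or still open, it means among the compounds named here.

Measured values in an assay on isolated protein for inhibition of DNA topoisomerase 1 (Homo sapiens), with a stated time of 30 min, tested at 100 uM; a lower number here means a weaker effect, a higher number a stronger effect of the compound at the concentration tested:
compound 1 `Oc1cccc(-c2cc(-c3cccc(Cl)c3)nc(-c3cccs3)c2)c1` gives 7.6%
compound 2 `Oc1cccc(-c2cc(-c3cccnc3)nc(-c3cccc(Cl)c3)c2)c1` gives 27.6%
compound 3 `Oc1cccc(-c2cc(-c3ccccc3)nc(-c3ccc(Cl)cc3)c2)c1` gives 7.1%

Compound 3 stands lowest of the three numbers, though its gap to compound 1 lies within the scatter; only compound 2 is set apart, its value lying beyond the scatter higher than that of compound 3. For the measured compounds named here, the single step measured so far, a number 20 percentage points higher from compound 1 to compound 2 (beyond the scatter), concerns a different position of the shared core and does not bear on the change considered here.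

Compound 4 `Oc1cccc(-c2cc(-c3ccccc3)nc(-c3cccc(Cl)c3)c2)c1` differs from compound 3 in one place: 3-chlorophenyl in place of 4-chlorophenyl on an aromatic carbon. Going by the values given here, no measured pair isolates this change. Among the compounds with values here, the only indirect comparison is that compound 1 carries a 3-chlorophenyl group and compound 3 a 4-chlorophenyl group, while the two also differ in their third aryl group, and their values lie within the scatter of each other. Nothing in the numbers therefore points to a step beyond the scatter in this assay for this change, in either direction. The step of a number 1.9 percentage points higher from compound 3 to compound 4 (within the scatter) is expected to remain within the scatter. The estimate for compound 4 in this assay is 9%, ranging from 0% to 25%.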

Compound 4, a percentage reported as inhibition, at one concentration (the size of the read-out at that concentration, not a potency): 11.5%
For compound 4 the middle estimate is 2.5 percentage points below the measured one; low and high end bracket the measured number.
By their numbers in this assay, from the lowest: compounds 3, 1 and 4 (each within the scatter of the next); then compound 2.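

In this assay, for the compounds shown here, the exchange of 4-chlorophenyl for 3-chlorophenyl, on the aromatic carbon next to the ring nitrogen, gives a number 4.4 percentage points higher from compound 3 to compound 4 (within the scatter) and so provides the first direct pair for this change, which does not separate the two chlorophenyl groups. With 3-chlorophenyl held fixed, phenyl in place of pyridin-3-yl gives a number 16.1 percentage points lower from compound 2 to compound 4 (beyond the scatter) while phenyl in place of thiophen-2-yl gives a number 3.9 percentage points higher from compound 1 to compound 4 (within the scatter) and thus, of these three groups, only pyridin-3-yl sets its compound apart. No measurement shown bears on the reason for these steps.

As far as these compounds go, whether pyridin-3-yl gives a similar step alongside 4-chlorophenyl remains open. Also open, from the compounds shown here alone, is whether an amine or a carboxylic acid in place of the chlorine would move the read-out beyond the scatter.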